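A few compounds are considered here, and "the series" means these few. Any claim that something is new, unique, unknown or untested is made for them only; others in the source may bear on it.

Compound 1 `CCOC(=O)CNc1nc(Nc2ccc(Cl)cc2)ncc1[N+](=O)[O-]` is examined in a functional assay on MCF7 cells (Homo sapiens) for antiproliferative activity, read by MTT assay, with a stated time of 48 h; on this read-out higher numbers stand for weaker inhibition and lower numbers for stronger inhibition. In this assay compound 1 gives > 100000 nM, which is a limit of the assay rather than a measured number. Compound 2 `CCOC(=O)CN(Cc1ccccc1)c1nc(Nc2ccc(Cl)cc2)ncc1[N+](=O)[O-]` differs from compound 1 by a benzyl in place of hydrogen on a nitrogen on an aromatic ring. In this assay compound 2 gives > 100000 nM, again a limit. As far as these compounds go, the step from compound 1 to compound 2 is therefore a step that the two limits leave unreadable from compound 1 to compound 2, as the limit of > 100000 nM in this assay, at which 2 of the 2 values shown sit, records, so its size is unknown.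

Compound 3 `CCOC(=O)CNc1nc(Nc2ccc(OC)cc2)ncc1[N+](=O)[O-]` differs from compound 1 by methoxy in place of chloro on an aromatic carbon, which read one bond further out is 4-chlorophenyl to 4-methoxyphenyl. Within the data shown here, no measured step touches this position, and the one measured step has no readable size, so nothing here points toward a change beyond the scatter in either direction. The expectation is that compound 3 again reaches only the limit, an estimated 100000 nM with a range from 30000 nM to 300000 nM. The expected step is a number no higher from compound 1 to compound 3 (the limit leaves the size open).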

Compound 3, half-maximal inhibitory concentration: > 100000 nM
Compound 3 gave a limit, no number; the forecaster's own chance of this, stated with the estimate: 80%; the middle value lies on the limit itself.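

Compound 1 and compound 3 both stop at a limit in this assay, so no size can be read for the change from 4-chlorophenyl to 4-methoxyphenyl, as this shows: the limit of > 100000 nM in this assay, at which 3 of the 3 values shown sit.

The compounds shown leave open whether any change to the shared core gives a measurable number in this assay.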